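A few compounds are considered here, and "the series" means these few. Any claim that something is new, unique, unknown or untested is made for them only; others in the source may bear on it.

Measured compounds:
- compound 1 `COc1cc2cc(Oc3ccc(NC(=O)Nc4ccccc4)cc3)c(C)nc2cc1OC` gives 54%
- compound 2 `COc1cc2cc(Oc3ccc(NC(=O)Nc4ccc(C)cc4)cc3)c(C)nc2cc1OC` gives 116%
- compound 3 `COc1cc2cc(Oc3ccc(NC(=O)Nc4ccc(C(F)(F)F)cc4)cc3)c(C)nc2cc1OC` gives 90.5%

These three share a common core and differ only in the group on the outer phenyl ring of the urea. In a functional assay on A498 cells (Homo sapiens) for inhibition, read by sulforhodamine B assay, with a stated time of 48 h, tested at 10 uM (on this read-out higher numbers stand for a weaker effect at the one concentration tested and lower numbers for a stronger effect), compound 3 stands second highest of the three numbers: it lies a number 25.5 percentage points lower from compound 2 to compound 3 (beyond the scatter) and a number 36.5 percentage points higher from compound 1 to compound 3 (beyond the scatter). Both of those steps are beyond the scatter, so the phenyl with a trifluoromethyl group gives a weaker effect at this concentration than the bare phenyl, and a somewhat stronger one than the phenyl with a methyl group.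

Compound 4 `COc1cc2cc(Oc3ccc(NC(=O)Nc4cccc(C(F)(F)F)c4)cc3)c(C)nc2cc1OC` has the same atoms as compound 3, joined differently: 3-(trifluoromethyl)phenyl in place of 4-(trifluoromethyl)phenyl on an amide-type nitrogen. Among the measured compounds shown here, no measured step changes where a group sits on that ring; the steps from compound 1 and compound 2 to compound 3 only show what adding or exchanging a group does. With nothing directly bearing on this change, no step beyond the scatter is expected, so compound 4 is estimated at 88% (range 60% to 115%), a step of a number 2.5 percentage points lower from compound 3 to compound 4 (within the scatter) from compound 3.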

Compound 4, a percentage reported as activity, at one concentration (the size of the read-out at that concentration, not a potency): 21.7%
Compound 4: middle estimate off by 66.3 percentage points, on the high side; measured number below the stated range.
By their numbers in this assay, from the lowest: compound 4; then compound 1; then compound 3; then compound 2.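

In this assay, moving the trifluoromethyl group from 4-(trifluoromethyl)phenyl to 3-(trifluoromethyl)phenyl on the amide-type nitrogen gives a number 68.8 percentage points lower from compound 3 to compound 4 (beyond the scatter), so on this ring the place of a group matters, not only which group it is. Earlier, methyl and trifluoromethyl in compound 2 and compound 3 both weakened the effect relative to the bare phenyl, whereas 3-(trifluoromethyl)phenyl strengthens it, with a number 32.3 percentage points lower from compound 1 to compound 4 (beyond the scatter) as the step. The gap to 4-methylphenyl is larger still, at a number 94.3 percentage points lower from compound 2 to compound 4 (beyond the scatter).

Going by these compounds, it remains open whether 3-methylphenyl, 3-chlorophenyl or 3-methoxyphenyl would follow 3-(trifluoromethyl)phenyl, and where 2-(trifluoromethyl)phenyl would fall. Nothing available here explains why this change of place has so large an effect.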